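This account rests on a few compounds, and the source may have more. Where it says the series, first, only, none or still open, it means among the compounds named here.

Among the measured compounds shown here, in a functional assay on SW480 cells (Homo sapiens) for antiproliferative activity, read by MTT assay, with a stated time of 48 h (a lower number here means a stronger inhibitor, a higher number a weaker inhibitor), compound 1 `CC(C)=CCC[C@]1(C)/C=C/[C@@H](OC(=O)C=C(C)C)[C@](C)(O)/C=C/C(=O)/C(CN(C)C)=C\C1` gives 480 nM, the lower of the two exact numbers available so far. Compound 2 `CC(C)=CCC[C@]1(C)/C=C/[C@@H](OC(=O)C=C(C)C)[C@](C)(O)/C=C/C(=O)/C(C[Si](c2ccccc2)(c2ccccc2)C(C)(C)C)=C\C1` gives 20700 nM, a higher number and a gap well beyond the usual scatter. Compound 3 `CC(C)=CCC[C@]1(C)/C=C/[C@@H](OC(=O)C=C(C)C)[C@](C)(O)CCC(=O)/C(CO)=C\C1` reads > 40000 nM, which is a limit of the assay and not a number. Compound 4 `COCOC/C1=C/C[C@](C)(CCC=C(C)C)/C=C/[C@@H](OC(=O)C=C(C)C)[C@](C)(O)/C=C/C1=O` has yet to be measured. It carries methoxymethoxy in place of dimethylamino on a saturated chain carbon bound to a double-bonded ring carbon. Compound 2 also lacks the dimethylamino group and gives 20700 nM, so a clear weakening beyond the scatter, towards a higher number, is expected in this assay. The expected change is a 21-fold higher number from compound 1 to compound 4 (1.32 log units; beyond the scatter). For compound 4 the estimated value is 10000 nM, within a range of 2500 nM to 40000 nM.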

Compound 4, half-maximal inhibitory concentration: 3710 nM
Beside the measured number, compound 4's estimate is 2.7-fold (0.43 log units) above it; low and high end bracket the measured number.
By their numbers in this assay, from the lowest: compound 1; then compound 4; then compound 2. At a limit, above all of these: compound 3.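

In this assay, putting methoxymethoxy in place of dimethylamino on a saturated chain carbon bound to a double-bonded ring carbon gives a 7.7-fold higher number from compound 1 to compound 4 (0.89 log units; beyond the scatter). Among the compounds shown here, this is the first single change at this position that can be read as a step. It shows that dimethylamino can be replaced without the activity disappearing, though the loss lies beyond the scatter. On these data alone, whether a larger amine such as piperidine, or a carboxylic acid, in this place would stay closer to compound 1 remains open. No measurement shown gives a reason for the size of this step.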